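The source may report more compounds than this note shows. Statements on the series, on what has been measured and on what is new or still open speak of the compounds shown alone.

Compound 1 `COc1cccc(/C=C2\CCC/C(=C\c3ccccc3Br)C2=O)c1OC`: 9700 nM
Compound 2 `COc1cccc(/C=C2\CCC/C(=C\c3cccc(Br)c3)C2=O)c1OC`: 11700 nM
Compound 3 `COc1cccc(/C=C2\CCC/C(=C\c3ccc(O)cc3)C2=O)c1OC`: > 20000 nM, a limit of the assay and not a number

In a functional assay on MCF7 cells (Homo sapiens) for cytotoxicity, read by MTT assay, with a stated time of 72 h (a higher number here means a weaker inhibitor, a lower number a stronger inhibitor), compound 2 gives 11700 nM and compound 1 gives 9700 nM, so these two stand within the scatter of each other. Compound 3 reached only a limit.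

The next analogue is compound 4 `COc1cccc(/C=C2\CCC/C(=C\c3cccc(Cl)c3Cl)C2=O)c1OC`, with one change: 2,3-dichlorophenyl in place of 3-bromophenyl on a double-bonded chain carbon bound to a double-bonded ring carbon. For the measured compounds named here, no measured step swaps bromine for chlorine, so the evidence is indirect. Exchanging 2-bromophenyl for 3-bromophenyl gave a 1.2-fold higher number from compound 1 to compound 2 (0.08 log units; within the scatter). Exchanging a bromophenyl for 4-hydroxyphenyl gave an at least 2.0-fold higher number from compound 1 to compound 3 (0.31 log units; beyond the scatter) and an at least 1.7-fold higher number from compound 2 to compound 3 (0.23 log units; that floor lies within the scatter). Compound 4 keeps a halogen-bearing phenyl, so it resembles the pair in the first step more than compound 3, and the size of a 1.2-fold higher number from compound 1 to compound 2 (0.08 log units; within the scatter) suggests that no change beyond the scatter should be expected in this assay. The expected change is a 1.3-fold lower number from compound 2 to compound 4 (0.11 log units; within the scatter). For compound 4 the estimated value is 9000 nM, with an expected range of 4000 nM to 18000 nM.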

Compound 4, half-maximal inhibitory concentration: > 20000 nM
Compound 4 gave a limit, no number; the forecaster's own chance of this, stated with the estimate: 10%; middle value at least 2.2-fold (0.34 log units) away from the limit.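

Compound 4 stands at a limit of the assay in this assay, not at a number, and it does not stand there alone: the limit of > 20000 nM in this assay, at which 2 of the 4 values shown sit.

Putting 2,3-dichlorophenyl at this place gives an at least 2.0-fold higher number from compound 1 to compound 4 (0.31 log units; beyond the scatter), and it gives an at least 1.7-fold higher number from compound 2 to compound 4 (0.23 log units; that floor lies within the scatter). Among the earlier compounds, only compound 3, with its 4-hydroxyphenyl, had reached the limit, whereas the halogen-bearing compound 4 now shows that a halogen on this phenyl does not by itself secure a measurable number, although compound 1 and compound 2 have one.

On these data alone, the step from compound 3 to compound 4 cannot be read, and how far compound 4 lies past its limit stays unknown. Also open, as far as these compounds go, is whether a 3-chlorophenyl, or a phenyl carrying an amine or a carboxylic acid, would give a number in this assay.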